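The compounds below may be only part of what the source reports. "The series", "measured", "known", "first", "only" and "open" are said of these compounds alone.

Measured so far:
compound 1, `COc1ccc2cc(C(C)c3nnc4n3N=C(c3ccc(Br)cc3)CS4)ccc2c1`: 11500 nM
compound 2, `COc1ccc2cc(C(C)c3nnc4n3N=C(c3ccc(F)cc3)CS4)ccc2c1`: 15800 nM
compound 3, `CC(c1ccc(-c2ccccc2)c(F)c1)c1nnc2n1N=C(c1ccc(Br)cc1)CS2`: 7400 nM

All three numbers come from a functional assay on MCF7 cells (Homo sapiens) for inhibition, read by sulforhodamine B assay, with a stated time of 72 h; a lower number here means a stronger inhibitor, a higher number a weaker inhibitor. Compound 1 and compound 2 share one core; compound 3 carries another, and the difference between the two cores is not broken down here. Compound 3 gives the lowest number of the three, but its gap to compound 1 is within the scatter and only its gap to compound 2 lies beyond it.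

One change has been measured once: fluoro in place of bromo on an aromatic carbon, which in this assay produced a 1.4-fold higher number from compound 1 to compound 2 (0.14 log units; within the scatter). Compound 4, `CC(c1ccc(-c2ccccc2)c(F)c1)c1nnc2n1N=C(c1ccc(F)cc1)CS2`, is not yet measured and stands to compound 3 exactly as compound 2 stands to compound 1, carrying fluoro in place of bromo on an aromatic carbon at the same place, so it is the same change on the second core.

For compound 4 the step in this assay is expected to be a 1.4-fold higher number from compound 3 to compound 4 (0.13 log units; within the scatter), resting on that single earlier instance a 1.4-fold higher number from compound 1 to compound 2 (0.14 log units; within the scatter), which sat within the scatter. Compound 4 is therefore estimated at 10000 nM in this assay, with a wide band because one prior example on a different core is thin ground.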

Compound 4, half-maximal inhibitory concentration: 8100 nM
Estimate against measurement, compound 4: 1.2-fold (0.09 log units) above; the range from low to high includes it.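

On the core of compound 3, going from 4-bromophenyl to 4-fluorophenyl gives in this assay a 1.1-fold higher number from compound 3 to compound 4 (0.04 log units; within the scatter). Set beside the earlier instance, the change carries from one core to the other without a readable difference: the same change on two cores in this assay, a 1.4-fold higher number (0.14 log units; within the scatter) from compound 1 to compound 2 and a 1.1-fold higher number (0.04 log units; within the scatter) from compound 3 to compound 4, 1.3-fold (0.10 log units) apart, within the scatter of two such steps. This shows only that bromo and fluoro at this place cannot be told apart on these two cores; with neither step beyond the scatter, it does not show that the change has a real effect on either core, that a larger effect would carry over in the same way, or that a third core would behave alike.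

Still open, going by these compounds, is whether a different group at this place, such as methoxy, an amine or a carboxylic acid, would give a step beyond the scatter on either core. Also open, on these data alone, is whether such a step would keep its size from one core to the other, which is the more demanding test of carrying a change across this series.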